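The source may report more compounds than this note shows. Statements on the series, on what has been measured and on what is new or still open speak of the compounds shown alone.

Compound 3 `Nc1nc(O)c2c(n1)n(C1OC(CO)[C@@H](O)[C@H]1O)c(=O)n2CCN1CCCCC1` gives 0% in a functional assay on the whole organism (B cells) with Mus musculus as the target (a lower number here means a smaller maximal response, a higher number a larger maximal response), the lowest of the three numbers recorded. Compound 1 `Nc1nc(O)c2c(n1)n(C1OC(CO)[C@@H](O)[C@H]1O)c(=O)n2Cc1ccc(Cl)cc1` gives 15%, and compound 2 `[N-]=[N+]=NCC(O)Cn1c(=O)n(C2OC(CO)[C@@H](O)[C@H]2O)c2nc(N)nc(O)c21` gives 91%. Compound 4 `Nc1nc(O)c2c(n1)n(C1OC(CO)[C@@H](O)[C@H]1O)c(=O)n2CC(O)CO` carries 1,2-dihydroxyethyl in place of (piperidin-1-yl)methyl on a saturated chain carbon bound to an aromatic nitrogen. Within the data shown here, the steps that bear on this change are a number 91 percentage points lower from compound 2 to compound 3 (beyond the scatter) and, less directly, a number 15 percentage points lower from compound 1 to compound 3 (beyond the scatter); both place compound 3 at the bottom. Because the 2-azido-1-hydroxyethyl of compound 2 gave 91%, a group that again brings a hydroxyl to this place is expected to lift the response by a large step, though the azide is absent and the size remains uncertain. Compound 4 is therefore expected to give 60%, between 20% and 95%. This corresponds to an expected step of a number 60 percentage points higher from compound 3 to compound 4 (beyond the scatter).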

Compound 4, largest response reached (reported as maximal response), in percent of the reference or control that the assay uses: 136%
Beside the measured number, compound 4's estimate is 76 percentage points below it, outside the stated range (above it).
By their numbers in this assay, from the lowest: compound 3; then compound 1; then compound 2; then compound 4.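

In this assay, 1,2-dihydroxyethyl at this place, on a saturated chain carbon bound to an aromatic nitrogen, gives a number 136 percentage points higher from compound 3 to compound 4 (beyond the scatter) and a number 121 percentage points higher from compound 1 to compound 4 (beyond the scatter). The azido group is not required for a large response, since hydroxy in place of azido gives a number 45 percentage points higher from compound 2 to compound 4 (beyond the scatter). Compound 4 therefore stands highest of the four, beyond the scatter from each of the others.

No evidence shown here accounts for this rise. On these data alone, it remains open whether a carboxylic acid, a primary amine or a longer chain bearing hydroxy groups would hold this response.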